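A piperidine swap on the ether side chain

The source may hold more compounds than are shown below. What is called first, only, known or untested is meant among the compounds shown, and "the series" means these compounds.

Going by the values given here, in a functional assay on SK-BR-3 cells (Homo sapiens) for antiproliferative activity (on this read-out lower numbers stand for stronger inhibition and higher numbers for weaker inhibition), compound 2 (`CC(C)=CCc1cc(C(=O)Nc2cc3ccc(OCCC4CCCCN4)c(C)c3oc2=O)ccc1O`) gives 640 nM and stands level, within the scatter, with compound 1 (`CC(=O)Oc1ccc(C(=O)Nc2cc3ccc(OCC4CCCN(C)C4)c(C)c3oc2=O)cc1CC=C(C)C`) at 740 nM as the only other measured compound. Compound 3 (`CC(C)=CCc1cc(C(=O)Nc2cc3ccc(OCC4CCCN(C)C4)c(C)c3oc2=O)ccc1O`) has not yet been measured. It differs from compound 2 in one place, on a saturated chain carbon bound to an oxygen on an aromatic ring, where 1-methylpiperidin-3-yl stands in place of (piperidin-2-yl)methyl (1-methylpiperidin-3-yl in place of (piperidin-2-yl)methyl on a saturated chain carbon bound to an oxygen on an aromatic ring). Compound 1 also carries the 1-methylpiperidin-3-yl group and gives 740 nM in this assay without departing from the level of compound 2. Among the compounds with values here, no measured pair isolates this change, so only a modest expectation is possible. The expected step is a 1.1-fold higher number from compound 2 to compound 3 (0.04 log units; within the scatter) and it is estimated to stay within the scatter, with no firm direction. For compound 3 the estimated value is 700 nM with an expected range from 300 nM to 1600 nM in this read-out.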

Compound 3, half-maximal inhibitory concentration: 1300 nM
Compound 3: the middle estimate sits 1.9-fold (0.27 log units) below what was measured; measured number inside the range.
By their numbers in this assay, from the lowest: compounds 2, 1 and 3 (each within the scatter of the next, the first and the last beyond it).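

In this assay, putting 1-methylpiperidin-3-yl in place of (piperidin-2-yl)methyl gives a 2.0-fold higher number from compound 2 to compound 3 (0.31 log units; beyond the scatter), so the group on this saturated chain carbon bound to an oxygen on an aromatic ring does affect the read-out, though only just beyond the scatter; compounds 1 and 2 differ in more than one place and could not show this. With 1-methylpiperidin-3-yl held constant, hydrogen in place of acetyl on the oxygen on an aromatic ring gives a 1.8-fold higher number from compound 1 to compound 3 (0.24 log units; within the scatter) and stays within the scatter, so that change has no effect this read-out can resolve. Nothing at hand explains the step on the side chain.

Going by these compounds alone, the single step changes the methyl on the ring nitrogen, the point of attachment and the chain together, and these remain unseparated. A 2-(1-methylpiperidin-2-yl)ethyl group would separate the methyl from the other two.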